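The compounds below may be only part of what the source reports. "The series", "measured", "known", "first", "only" and "open" are said of these compounds alone.

In a functional assay, read by spectrophotometry, with a stated time of 30 min (a higher number here means a weaker inhibitor, a lower number a stronger inhibitor), compound 2 (`CC(C)(C)c1cc(/C=C/C(=O)NCCC2CCN(Cc3ccc(F)c(F)c3)CC2)cc(C(C)(C)C)c1O`) gives 65700 nM and compound 1 (`CC(C)(C)c1cc(/C=C/C(=O)NCCC2CCN(Cc3ccc(F)cc3F)CC2)cc(C(C)(C)C)c1O`) gives 62400 nM, so the two stand level within the scatter. Compound 3 (`CC(C)(C)c1cc(/C=C/C(=O)NCCC2CCN(Cc3ccccc3Cl)CC2)cc(C(C)(C)C)c1O`) carries 2-chlorophenyl in place of 3,4-difluorophenyl on a saturated chain carbon bound to an amine nitrogen in a ring. Among the compounds with values here, the one measured step at this place, a 1.1-fold higher number from compound 1 to compound 2 (0.02 log units; within the scatter), lies within the scatter, though it only exchanges one difluorophenyl group for another. No clear shift in either direction is therefore expected in this assay, and the estimated step is a 1.2-fold lower number from compound 2 to compound 3 (0.08 log units; within the scatter). Compound 3 is expected at 55000 nM, within an estimated range of 22000 nM to 120000 nM.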

Compound 3, half-maximal inhibitory concentration: 80200 nM
Compound 3: middle estimate off by 1.5-fold (0.16 log units), on the low side; the range from low to high includes it.
By their numbers in this assay, from the lowest: compounds 1, 2 and 3 (each within the scatter of the next).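

Within the data shown here, until now, this place on a saturated chain carbon bound to an amine nitrogen in a ring had seen only one difluorophenyl group exchanged for another. In this assay, 2-chlorophenyl, with chlorine in place of fluorine and one heavy atom fewer, now gives two further steps (a 1.2-fold higher number from compound 2 to compound 3 (0.09 log units; within the scatter) and a 1.3-fold higher number from compound 1 to compound 3 (0.11 log units; within the scatter)). All three compounds therefore stand level, and a change of halogen, as well as of its placement, leaves the number within the scatter here.

Going by these compounds, it remains open whether this holds for a phenyl ring carrying a methoxy group or a carboxylic acid, or for a pyridyl group at this place. No measurement offered here bears on why these compounds stand level.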